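This account rests on a few compounds, and the source may have more. Where it says the series, first, only, none or still open, it means among the compounds named here.

Measured in a functional assay on HT-29 cells (Homo sapiens) for inhibition, read by luminescence and CellTiter-Glo, with a stated time of 24 h; a lower number here means that less compound is needed, a higher number that more compound is needed for the effect:
- compound 1 `CC(C)Cn1nc(C(=O)N[C@H]2COc3ccccc3N(C)C2=S)nc1Cc1ccccc1` gives 1230 nM
- compound 2 `CN1C(=S)[C@@H](NC(=O)c2nc(Cc3ccccc3)n(C3CCN(C(=O)OC(C)(C)C)C3)n2)COc2ccccc21` gives > 10000 nM, which is a limit

Compound 2 stands at the limit of > 10000 nM in this assay, at which 1 of the 2 values shown sits, so it has a limit of the assay and not a number. Compound 3 `CN1C(=S)[C@@H](NC(=O)c2nc(Cc3ccccc3)n(-c3ncccn3)n2)COc2ccccc21` carries pyrimidin-2-yl on an aromatic nitrogen, and the change is a group of 6 heavy atoms (4 carbon, 2 nitrogen; one six-membered aromatic ring with 2 hetero atoms) in place of a group of 12 heavy atoms (9 carbon, 1 nitrogen, 2 oxygen; one five-membered non-aromatic ring with 1 hetero atom), on an aromatic nitrogen. Among the measured compounds shown here, one measured step bears on this position, an at least 8.1-fold higher number from compound 1 to compound 2 (0.91 log units; beyond the scatter), and it is open-ended. Compound 3 keeps a group with fewer heavy atoms than compound 2 at this nitrogen, though its ring differs from anything measured there. A drop beyond the scatter in this assay is therefore expected, to a level near or somewhat weaker than compound 1, though a further limit remains possible. The expected step is an at least 3.3-fold lower number from compound 2 to compound 3 (0.52 log units; beyond the scatter). For compound 3 the estimated value is 3000 nM, with an expected range from 600 nM to 10000 nM.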

Compound 3, half-maximal effective concentration: 3970 nM
Compound 3: middle estimate off by 1.3-fold (0.12 log units), on the low side; the measured number falls inside the stated range.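

In this assay, pyrimidin-2-yl on this aromatic nitrogen gives a measured number where the larger ring-bearing group did not, with an at least 2.5-fold lower number from compound 2 to compound 3 (0.40 log units; beyond the scatter). Against isobutyl the same group still costs activity, with a 3.2-fold higher number from compound 1 to compound 3 (0.51 log units; beyond the scatter), so across these three compounds the number rises with the heavy-atom count of the group on this nitrogen. The value for compound 2 is a limit and not a number, so the top of that order stays open-ended: the limit of > 10000 nM in this assay, at which 1 of the 3 values shown sits.

The three groups differ in size and in ring type at once, and the compounds shown do not separate the two. A phenyl ring, which would keep the six-membered aromatic ring without its ring nitrogens, or a shorter chain such as ethyl would bear on that question.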